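Chain-end change from compound 3 to compound 4

The source may hold more compounds than are shown below. What is called first, only, known or untested is meant among the compounds shown, and "the series" means these compounds.

Measured so far in a functional assay on MCF7 cells (Homo sapiens) for inhibition, with a stated time of 48 h, tested at 50 uM; on this read-out lower numbers stand for less inhibition of growth and higher numbers for more inhibition of growth at the one concentration tested:
compound 1 `C=C[C@@](C)(/C=C/c1ccc(OC(C)=O)cc1)CCC=C(C)C` gives 75%
compound 2 `C=C[C@@](C)(/C=C/c1ccc(OC(=O)CCCC)cc1)CCC=C(C)C` gives 25%
compound 3 `C=C[C@@](C)(/C=C/c1ccc(O)cc1)CC/C=C(/C)C=O` gives 12%

Compound 3 at 12% is the lowest of the three numbers, and both compound 2 and compound 1 stand above it beyond the scatter. The next structure is compound 4 `C=C[C@@](C)(/C=C/c1ccc(O)cc1)CCC1OC1(C)C` and the change is 3,3-dimethyloxiran-2-yl in place of 2-formylprop-1-en-1-yl on a saturated chain carbon, three bonds along the chain from two double-bonded chain carbons with 3,3-dimethyloxiran-2-yl in place of 2-formylprop-1-en-1-yl on a saturated chain carbon, three bonds along the chain from two double-bonded chain carbons.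

Going by the values given here, the only measured step is a number 50 percentage points lower from compound 1 to compound 2 (beyond the scatter) and it is large, but it lies elsewhere, at a saturated chain carbon bound to a carbonyl carbon. Among the compounds with values here, it shows that one change can move the numbers a long way, yet no measured pair tests the place altered here, so the data give no firm direction. Compound 3 stands at 12% so little room remains below it, and any sizeable shift could only be upward. No step beyond the scatter is expected, and the expected step is a number 8 percentage points higher from compound 3 to compound 4 (within the scatter) in this assay with a wide upward margin. For compound 4 the expected value is 20% with an estimated range of 5% to 45% as the working figure.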

Compound 4, percent growth inhibition at one concentration: 33%
Estimate against measurement, compound 4: 13 percentage points below; measured number inside the range.
By their numbers in this assay, from the lowest: compound 3; then compounds 2 and 4 (each within the scatter of the next); then compound 1.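

In this assay, 3,3-dimethyloxiran-2-yl in place of 2-formylprop-1-en-1-yl on a saturated chain carbon, three bonds along the chain from two double-bonded chain carbons, gives a number 21 percentage points higher from compound 3 to compound 4 (beyond the scatter), so this chain end is a second place in the series where a single change moves the read-out, which the earlier step at the carbonyl-bound chain carbon could not show. The two groups match in heavy atoms and in hydrogen-bond acceptors and donors, so the step goes with the kind of group rather than with those counts: a three-membered ring holding the oxygen enters, and the double bonds of the formyl-bearing group leave. Nothing at hand ties this step to any property of either group.

The ring and the double bonds change together in this one swap, so the compounds shown leave open which of the two goes with the step, and whether a carboxylic acid or a hydroxymethyl group in place of the formyl at the same chain end would move the read-out as well. As far as these compounds go, it also remains open whether this chain-end change would give a similar step in a compound carrying the acetyl group of compound 1.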